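Replacing the Propanoylamino Group with Nitro: Cytotoxicity Outlook

The compounds below may be only part of what the source reports. "The series", "measured", "known", "first", "only" and "open" are said of these compounds alone.

The measured compounds, with their values in an ADME assay on MT4 cells (Homo sapiens) for cytotoxicity, read by MTT assay, with a stated time of 96 h; a lower number here means that less compound is tolerated, a higher number that more compound is tolerated:
compound 1, `CCC(=O)Nc1ccc(-c2nc3cc(C(F)(F)F)ccc3n2C2CCCCC2)cc1`, gives 17000 nM
compound 2, `CCC(=O)Nc1ccc(-c2nc3cc(C(F)(F)F)ccc3[nH]2)cc1`, gives >= 100000 nM, which is a limit of this assay rather than a number
compound 3, `O=[N+]([O-])c1ccc(-c2nc3cc(C(F)(F)F)ccc3[nH]2)c([N+](=O)[O-])c1`, gives 9000 nM

Compound 1 has the highest of the two plain numbers in this assay, and compound 3 sits within the scatter of it, so the two cannot be ranked. Among the compounds with values here, the one step measured in a single place is an at least 5.8-fold higher number from compound 1 to compound 2 (0.76 log units; beyond the scatter), which lands at the limit of >= 100000 nM in this assay, at which 1 of the 3 values shown sits, and concerns the ring nitrogen, not the group on the outer ring.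

Compound 4, `O=[N+]([O-])c1ccc(-c2nc3cc(C(F)(F)F)ccc3n2C2CCCCC2)cc1`, differs from compound 1 by nitro in place of propanoylamino on an aromatic carbon. Within the data shown here, no measured step touches this change, so the only guide is that compound 3, which carries nitro groups, gives a plain number rather than a limit. Compound 4 is therefore expected to stay near compound 1, with at most a small shift towards a lower number: the estimate for compound 4 is 11000 nM, ranging from 4000 nM to 30000 nM. That estimate means an expected step of a 1.5-fold lower number from compound 1 to compound 4 (0.19 log units; within the scatter).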

Compound 4, half-maximal cytotoxic concentration: 49000 nM
The estimate for compound 4 lay 4.5-fold (0.65 log units) below the measured number; measured number outside the range, above it.
By their numbers in this assay, from the lowest: compounds 3 and 1 (each within the scatter of the next); then compound 4. At a limit, above all of these: compound 2.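

This result shows that the group on the outer ring, para to a large group, also moves the number in this assay, and not only the group on the ring nitrogen: nitro in place of propanoylamino gives a 2.9-fold higher number from compound 1 to compound 4 (0.46 log units; beyond the scatter). In this one pair, the group with 3 heavy atoms and 0 hydrogen-bond donors is better tolerated than the group with 5 heavy atoms and 1 hydrogen-bond donor. Nothing given here accounts for the rise.

From the compounds shown here alone, whether an amine, a carboxylic acid or a longer amide chain at this place would give a higher or a lower number remains open. Going by these compounds, it is also open whether the same change would shift the number on the core with hydrogen in place of cyclohexyl.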